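Thiophen-2-yl in place of naphthalen-2-yl on a carbonyl carbon

The source may hold more compounds than are shown below. What is called first, only, known or untested is meant among the compounds shown, and "the series" means these compounds.

In a functional assay on U2OS cells (Homo sapiens) for antiproliferative activity, read by MTT assay, with a stated time of 72 h (a lower number here means a stronger inhibitor, a higher number a weaker inhibitor), compound 1 (`O=C(CSc1cccc(O)c1)Nc1ccc2nc(NC(=O)c3ccccc3)sc2c1`) reads > 100000 nM, which is a limit of the assay. Going by the values given here, compound 2 (`O=C(CSc1cccc(O)c1)Nc1ccc2nc(NC(=O)c3ccc4ccccc4c3)sc2c1`) gives 1770 nM, the only actual number so far. Compound 3 (`O=C(CSc1cccc(O)c1)Nc1ccc2nc(NC(=O)c3cccs3)sc2c1`) differs from it at one place, with thiophen-2-yl in place of naphthalen-2-yl on a carbonyl carbon. Among the compounds with values here, the one measured step that bears on this is large, namely an at least 56-fold lower number from compound 1 to compound 2 (1.75 log units; beyond the scatter), with naphthalen-2-yl in place of phenyl. Compound 3 returns to a single aromatic ring, so much of that gain is expected to be lost in this assay. The estimated step, towards a higher number, is a 14-fold higher number from compound 2 to compound 3 (1.15 log units; beyond the scatter). For compound 3 the estimated value is 25000 nM, with an expected range of 4000 nM to 100000 nM.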

Compound 3, half-maximal inhibitory concentration: 63000 nM
Compound 3: the middle estimate sits 2.5-fold (0.40 log units) below what was measured; measured number inside the range.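

In this assay, the level reached by compound 2 does not carry over to thiophen-2-yl on this carbonyl carbon, with a 36-fold higher number from compound 2 to compound 3 (1.55 log units; beyond the scatter). Of the three groups shown here, only naphthalen-2-yl gives a reading well clear of the others. Against phenyl, the replacement gives an at least 1.5-fold lower number from compound 1 to compound 3 (0.20 log units; that floor lies within the scatter), but compound 1 stands at a limit, so the true size of this step stays unknown: the limit of > 100000 nM in this assay, at which 1 of the 3 values shown sits.

Going by these compounds, it remains open whether a quinolin-2-yl group or a saturated cyclohexyl ring on this carbonyl carbon would keep the level of compound 2. On these data alone, whether a substituted phenyl, such as 4-chlorophenyl, would do so is equally open.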